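The source may hold more compounds than are shown below. What is called first, only, known or untested is meant among the compounds shown, and "the series" means these compounds.

In a functional assay on MDA-MB-468 cells (Homo sapiens) for cytotoxicity, read by resazurin assay, with a stated time of 72 h (a higher number here means a weaker inhibitor, a lower number a stronger inhibitor), three compounds give close numbers: compound 1 `S=C(NCc1cccnc1)SCCc1nnc(-c2ccccc2)o1` gives 2770 nM while compound 2 `Fc1ccccc1-c1nnc(CCSC(=S)NCc2cccnc2)o1` gives 3420 nM and compound 3 `S=C(NCc1cccnc1)SCCc1nnc(-c2cc[nH]c2)o1` gives 2040 nM as its value. Compound 3 thus stands level with the other two, within the scatter. Compound 4 `S=C(NCc1cccnc1)SCCc1nnc(-c2cccs2)o1` carries thiophen-2-yl in place of 1H-pyrrol-3-yl on an aromatic carbon and still awaits measurement. Two measured steps exchanged the group at this same place, a 1.4-fold lower number from compound 1 to compound 3 (0.13 log units; within the scatter) and a 1.7-fold lower number from compound 2 to compound 3 (0.22 log units; within the scatter) and both stayed within the scatter. With steps that small, this assay is expected to show none beyond the scatter, and a 1.2-fold higher number from compound 3 to compound 4 (0.09 log units; within the scatter) is the estimated step. For compound 4 the estimated value is 2500 nM with an expected range from 1200 nM to 5000 nM in this measurement.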

Compound 4, half-maximal inhibitory concentration: 3410 nM
Compound 4: the middle estimate sits 1.4-fold (0.13 log units) below what was measured; the range from low to high includes it.
By their numbers in this assay, from the lowest: compounds 3, 1, 4 and 2 (each within the scatter of the next).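

Thiophen-2-yl brings a ring sulfur and loses the hydrogen-bond donor of 1H-pyrrol-3-yl, yet this assay does not separate it from any earlier group (a 1.7-fold higher number from compound 3 to compound 4 (0.22 log units; within the scatter); a 1.2-fold higher number from compound 1 to compound 4 (0.09 log units; within the scatter); a 1.0-fold lower number from compound 2 to compound 4 (0.00 log units; within the scatter)). Across the compounds shown, this position therefore accepts all four aromatic groups, and the presence or absence of that donor makes no visible difference. No other measurement here offers an explanation for this flat result. Still open, on these data alone, is whether a non-aromatic group at this place, such as an amine or a carboxylic acid, would shift the number beyond the scatter.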